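The source may report more compounds than this note shows. Statements on the series, on what has been measured and on what is new or still open speak of the compounds shown alone.

In a functional assay on NIH3T3 cells (Mus musculus) (on this read-out lower numbers stand for an effect already at smaller amounts and higher numbers for an effect only at larger amounts of compound), compound 1 `Cn1cncc1C(OCc1ccc(C#N)cc1C#Cc1ccc([N+](=O)[O-])cc1)c1ccc(C#N)cc1` gives 36 nM. Compound 2 `Cn1cncc1C(OCc1ccc(C#N)cc1C#Cc1cccc(O)c1)c1ccc(C#N)cc1` gives > 0.1 nM, which is a limit and not a number. For the measured compounds named here, the only measured step is a step that the limit leaves unreadable from compound 1 to compound 2, so no measured size can be carried forward. Compound 3 `Cn1cncc1C(OCc1ccc(C#N)cc1CCC(C)(C)C)c1ccc(C#N)cc1` has a different group at this site: 3,3-dimethylbutyl in place of 2-(3-hydroxyphenyl)ethynyl on an aromatic carbon. Going by the values given here, no measured step covers this exchange, and the value of compound 1, 36 nM, is the only number available as a guide. The expected step that the limit leaves unreadable from compound 2 to compound 3 therefore has no firm size or direction. For compound 3 the estimate is 40 nM, with the value expected between 5 nM and 300 nM.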

Compound 3, half-maximal effective concentration: 0.54 nM
For compound 3 the middle estimate is 74-fold (1.87 log units) above the measured one; measured number outside the range, below it.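

In this assay, this position on the aromatic ring accepts a chain with no ring and no triple bond: exchanging the 2-(4-nitrophenyl)ethynyl group for 3,3-dimethylbutyl gives a 67-fold lower number from compound 1 to compound 3 (1.82 log units; beyond the scatter). An aromatic ring joined through a triple bond is therefore not required here for an effect at small amounts, as compound 3 shows. Compound 2 has only a limit, so the steps that involve it cannot be read: the limit of > 0.1 nM in this assay, at which 1 of the 3 values shown sits.

The compounds shown leave open whether a straight hexyl chain, a shorter propyl chain or a chain ending in an amine would match compound 3.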